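The compounds below may be only part of what the source reports. "The series", "measured", "known", "first", "only" and "open" are said of these compounds alone.

Two measured compounds share one core and differ only in the length of a saturated chain. Compound 1 `C=C1C(=O)S[C@H](CCCCCC)[C@H]1C(=O)O` bears the shorter chain; in an assay for inhibition of fatty acid synthase (Rattus norvegicus) (on this read-out lower numbers stand for stronger inhibition and higher numbers for weaker inhibition), compound 1 gives 16700 nM. Compound 2 `C=C1C(=O)S[C@H](CCCCCCCC)[C@H]1C(=O)O` bears the longer chain, and in this assay compound 2 gives 2560 nM, which is the lowest of the two numbers seen so far, meaning the stronger inhibition. Among the compounds with values here, the single measured step, a 6.5-fold lower number from compound 1 to compound 2 (0.81 log units; beyond the scatter), came from ethyl in place of hydrogen on a saturated chain carbon, six bonds along the chain from a saturated ring carbon. Compound 3 `C=C1C(=O)S[C@H](CCCCCCCCC)[C@H]1C(=O)O` has not yet been measured. It differs from compound 2 by methyl in place of hydrogen on a saturated chain carbon, eight bonds along the chain from a saturated ring carbon, so the chain grows once more, now by a methyl. Because the step of a 6.5-fold lower number from compound 1 to compound 2 (0.81 log units; beyond the scatter) lowered the number when the chain was lengthened, a further lengthening is expected to lower it again, though less strongly: only one carbon is added, and the earlier gain need not repeat in full. The expected step is a 1.7-fold lower number from compound 2 to compound 3 (0.23 log units; within the scatter). Compound 3 is therefore estimated to give 1500 nM in this assay, with a likely range from 600 nM to 4000 nM.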

Compound 3, half-maximal inhibitory concentration: 2280 nM
For compound 3 the middle estimate is 1.5-fold (0.18 log units) below the measured one; the range from low to high includes it.
By their numbers in this assay, from the lowest: compounds 3 and 2 (each within the scatter of the next); then compound 1.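

In this assay, methyl in place of hydrogen on a saturated chain carbon, eight bonds along the chain from a saturated ring carbon, gives a 1.1-fold lower number from compound 2 to compound 3 (0.05 log units; within the scatter), so compound 2 and compound 3 cannot be told apart in this assay. This differs from the earlier step on the same chain, a 6.5-fold lower number from compound 1 to compound 2 (0.81 log units; beyond the scatter), which lay beyond the scatter: among these three compounds, lengthening the chain does not always pay off to the same degree. Taken as a whole, the full lengthening of the chain gives a 7.3-fold lower number from compound 1 to compound 3 (0.86 log units; beyond the scatter), a difference about the size of the one already seen with compound 2, and nothing available explains why the chain stops making a clear difference here.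

The compounds shown leave open whether a longer chain would stay level with compound 3 or move the number in either direction. They also leave open how an amine, a hydroxyl or a phenyl ring in place of this methyl would read in this assay.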